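This account rests on a few compounds, and the source may have more. Where it says the series, first, only, none or still open, it means among the compounds named here.

Compound 1 `Cc1cccc(C(=O)n2ncc3cc([N+](=O)[O-])ccc32)c1`: 77000 nM
Compound 2 `O=C(c1ccccc1Cl)n1ncc2cc([N+](=O)[O-])ccc21`: 7000 nM

In a functional assay on B16 cells (Mus musculus) for inhibition, with a stated time of 3 days (on this read-out lower numbers stand for stronger inhibition and higher numbers for weaker inhibition), compound 2 stands lowest of the two, at 7000 nM. Compound 3 `O=C(c1ccc(Cl)cc1)n1ncc2cc([N+](=O)[O-])ccc21` differs from it as follows: 4-chlorophenyl in place of 2-chlorophenyl on a carbonyl carbon. That is 4-chlorophenyl in place of 2-chlorophenyl on a carbonyl carbon. Going by the values given here, only one measured step bears on this place, an 11-fold lower number from compound 1 to compound 2 (1.04 log units; beyond the scatter), which is large and beyond the scatter. Among the compounds with values here, it shows that this place can move the number, but no measured step isolates the chlorine's position. A moderate rise in this assay is therefore expected. Compound 3 is estimated at 20000 nM, within 5000 nM to 80000 nM. The expected change is a 2.9-fold higher number from compound 2 to compound 3 (0.46 log units; beyond the scatter).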

Compound 3, half-maximal inhibitory concentration: 60000 nM
Beside the measured number, compound 3's estimate is 3.0-fold (0.48 log units) below it; the range from low to high includes it.
By their numbers in this assay, from the lowest: compound 2; then compounds 3 and 1 (each within the scatter of the next).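

In this assay, moving the chlorine alone gives an 8.6-fold higher number from compound 2 to compound 3 (0.93 log units; beyond the scatter), so with the same atoms joined differently, the chlorine's position on the ring attached to the carbonyl carbon clearly moves the number. With a 1.3-fold lower number from compound 1 to compound 3 (0.11 log units; within the scatter), 4-chlorophenyl and 3-methylphenyl cannot be told apart here, so the stronger inhibition belongs to 2-chlorophenyl and not to chlorine on the ring as such. Nothing available bears on the reason for this difference. As far as these compounds go, it remains open whether a methoxy group or an amine in place of the chlorine of 2-chlorophenyl would keep the number of compound 2.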